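The compounds below may be only part of what the source reports. "The series", "measured", "known", "first", "only" and "open" are said of these compounds alone.

The series shares one core carrying a sulfur-linked side chain that is varied; compound 1 is `O=[N+]([O-])c1ccccc1CSc1nnc(-c2ccncc2)n1-c1ccccc1`, compound 2 is `O=[N+]([O-])c1cccc(CSc2nnc(-c3ccncc3)n2-c2ccccc2)c1` and compound 3 is `O=C(CSc1nnc(-c2ccncc2)n1-c1ccccc1)N/N=C/c1ccccc1`. In a functional assay on HepG2 cells (Homo sapiens) for inhibition, read by MTT assay, with a stated time of 48 h (a higher number here means a weaker inhibitor, a lower number a stronger inhibitor), compound 1 gives > 50000 nM, which is a limit of the assay and not a number. In this assay compound 2 gives 22000 nM and compound 3 gives 18600 nM. Compound 3 therefore sits alongside compound 2, the gap between the two numbers lying within the scatter, while the remaining value is only a limit. Within the data shown here, the single step between measured compounds, an at least 2.2-fold lower number from compound 1 to compound 2 (0.35 log units; beyond the scatter), concerns the nitro group on a different side chain and does not touch the part changed next. Compound 4 is `O=C(CSc1nnc(-c2ccncc2)n1-c1ccccc1)N/N=C/c1ccc(Cl)cc1`; it differs from compound 3 by chloro in place of hydrogen on an aromatic carbon. Among the measured compounds shown here, no measured step bears on this change, so no shift beyond the scatter in this assay is expected, a 1.2-fold lower number from compound 3 to compound 4 (0.09 log units; within the scatter). Compound 4 is accordingly estimated at 15000 nM in this assay, with a range from 6000 nM to 40000 nM.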

Compound 4, half-maximal inhibitory concentration: 11000 nM
For compound 4 the middle estimate is 1.4-fold (0.13 log units) above the measured one; low and high end bracket the measured number.
By their numbers in this assay, from the lowest: compounds 4, 3 and 2 (each within the scatter of the next). At a limit, above all of these: compound 1.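

In this assay, among these compounds, phenyl to 4-chlorophenyl gives a 1.7-fold lower number from compound 3 to compound 4 (0.23 log units; within the scatter), so this is the first reading on this aromatic ring, and chloro para to a large group brings no shift beyond the scatter. The earlier step concerned the nitro group on a different side chain and said nothing about this aromatic carbon; here compound 4, at 11000 nM, stays within the scatter of compound 3. Nothing measured for these compounds bears on why the step has this size.

One substituent at one place leaves open whether a methoxy group, an amine or a carboxylic acid on the same aromatic carbon would move the number beyond the scatter. Also open, from the compounds shown here alone, is whether chloro on another carbon of this ring would read the same.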